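Thiophene for Methoxyphenyl on a Carbonyl Carbon

A few compounds are considered here, and "the series" means these few. Any claim that something is new, unique, unknown or untested is made for them only; others in the source may bear on it.

Of the compounds shown here, two with a shared core have been measured: compound 1 `Cc1cccc2cc(/C=C/C(=O)c3ccccc3)c(Cl)nc12` and compound 2 `COc1ccc(C(=O)/C=C/c2cc3cc(C)ccc3nc2Cl)cc1`. In an assay on cell membranes for displacement of a labelled ligand from metabotropic glutamate receptor 5 (Rattus norvegicus), read by scintillation counting, with a stated time of 60 min (a higher number here means a weaker inhibitor, a lower number a stronger inhibitor), compound 1 gives > 100000 nM, which is a limit of the assay and not a number. In this assay compound 2 gives > 100000 nM, likewise a limit rather than a number. Compound 2 therefore stands where every value shown stands, at the limit of > 100000 nM in this assay, at which 2 of the 2 values shown sit.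

Compound 3 `Cc1ccc2nc(Cl)c(/C=C/C(=O)c3cccs3)cc2c1` has not yet been measured in this assay. It differs from compound 2 by thiophen-2-yl in place of 4-methoxyphenyl on a carbonyl carbon. For the measured compounds named here, no step between measured compounds is available, so no computed size can guide the expectation, and a step of no more than the scatter is expected in this assay. Compound 3 is expected to give 100000 nM in this assay, within 30000 nM to 300000 nM. The expected step is a number no higher from compound 2 to compound 3 (the limit leaves the size open).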

Compound 3, inhibition constant: > 100000 nM
Compound 3: a limit, no number (the forecaster's own chance of this, stated with the estimate: 80%); the middle value sits exactly at the limit.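

In this assay compound 3 gives > 100000 nM, which is a limit of the assay and not a number. For the compounds shown here, compound 2 also stands at a limit, so no step between compound 2 and compound 3 can be read. The compounds shown leave open how thiophen-2-yl and 4-methoxyphenyl compare on a carbonyl carbon.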